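The source may hold more compounds than are shown below. What is called first, only, known or untested is meant among the compounds shown, and "the series" means these compounds.

Measured so far in an ADME assay on microsomes from liver (Homo sapiens) for metabolic stability, read by LC-MS, with a stated time of 30 min, tested at 1 uM; on this read-out higher numbers stand for a more stable compound and lower numbers for a less stable compound:
- compound 1 `O=C(NCc1ccc(S(=O)(=O)c2cccc(C(F)(F)F)c2)cc1)c1cc2cnccc2[nH]1`: 81%
- compound 2 `O=C(NCc1ccc(S(=O)(=O)N2CCCCC2)cc1)c1cnc2nccn2c1`: 64%
- compound 3 `O=C(NCc1ccc(S(=O)(=O)c2cc(F)cc(F)c2)cc1)c1cnc2nccn2c1`: 78%

Compound 3 at 78% lies within the scatter of compound 1 at 81% on the same read-out. Compound 2 stands at 64% on that read-out. The gap between compound 2 and compound 3 lies beyond the scatter. Compound 4 `O=C(NCc1ccc(S(=O)(=O)c2cccc(C(F)(F)F)c2)cc1)c1cnc2nccn2c1` keeps the core of compound 3 and differs by 3-(trifluoromethyl)phenyl in place of 3,5-difluorophenyl on a sulfonyl sulfur with 3-(trifluoromethyl)phenyl in place of 3,5-difluorophenyl on a sulfonyl sulfur.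

Among the compounds with values here, no measured pair isolates this swap. Within the data shown here, the only measured step on this sulfur is a number 14 percentage points higher from compound 2 to compound 3 (beyond the scatter) on going from piperidin-1-yl to 3,5-difluorophenyl, and that is a different kind of exchange, so it is only a loose guide. Compound 1 carries the entering group on another core and stands at 81% in the same range as compound 3. Accordingly the expected outcome is a number 1 percentage points higher from compound 3 to compound 4 (within the scatter) and no step beyond the scatter. In this assay compound 4 is expected at 79% with an estimated range from 68% to 89% as the likely span.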

Compound 4, percent of the compound remaining: 41%
Compound 4: middle estimate off by 38 percentage points, on the high side, outside the stated range (below it).
By their numbers in this assay, from the lowest: compound 4; then compound 2; then compounds 3 and 1 (each within the scatter of the next).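

On the sulfonyl sulfur, two aromatic groups proved far from interchangeable in this assay: 3-(trifluoromethyl)phenyl in place of 3,5-difluorophenyl gives a number 37 percentage points lower from compound 3 to compound 4 (beyond the scatter), and the same group in place of piperidin-1-yl gives a number 23 percentage points lower from compound 2 to compound 4 (beyond the scatter), which reverses the direction of the earlier step to 3,5-difluorophenyl. The high number of compound 1 also did not carry over to the other core, as the exchange of the group on the carbonyl carbon gives a number 40 percentage points lower from compound 1 to compound 4 (beyond the scatter), showing that the outcome for 3-(trifluoromethyl)phenyl depends on the core it is paired with. Nothing available here accounts for either fall.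

Going by these compounds, it remains open whether the loss follows the trifluoromethyl group itself, as an unsubstituted phenyl on the same sulfur could help to show. On these data alone, it is also open whether 3,5-difluorophenyl would give a similar number on the core of compound 1.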